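Dropping the cyclohexyl from compound 2 in the K562 assay

The compounds below may be only part of what the source reports. "The series", "measured", "known", "first", "only" and "open" are said of these compounds alone.

Compound 1, `CC(C)c1ccc(C(=O)/C=C/C(=O)O)c(C(C)C)c1`, gives 4680 nM in a functional assay on K562 cells (Homo sapiens) for inhibition, read by MTT assay, with a stated time of 72 h; on this read-out higher numbers stand for weaker inhibition and lower numbers for stronger inhibition.
Compound 2, `Cc1cc(C2CCCCC2)c(C)cc1C(=O)/C=C/C(=O)O`, gives 4240 nM in this assay.
Compound 3, `Cc1ccc(C(=O)/C=C/C(=O)O)cc1C`, gives 5620 nM in this assay.

The three measured compounds share a core carrying the (2-carboxyethenyl)carbonyl group and differ only in what sits around it on the aromatic ring. Their numbers in this assay lie close together: compound 2 stands at a number that compound 1 and compound 3 both match within the scatter, so none of the three can be set apart from the others. Compound 4, `Cc1ccc(C)c(C(=O)/C=C/C(=O)O)c1`, has not yet been measured. It differs from compound 2 in one place: hydrogen in place of cyclohexyl on an aromatic carbon. Within the data shown here, nothing among the measured compounds tracks this change as a single step, so the expectation rests on the narrow spread of compound 1, compound 2 and compound 3 alone. Compound 4 is expected near 5500 nM, within a range from 2500 nM to 12000 nM. The step of a 1.3-fold higher number from compound 2 to compound 4 (0.11 log units; within the scatter) is expected to fall within the scatter, leaning toward weaker inhibition if anywhere.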

Compound 4, half-maximal inhibitory concentration: 5900 nM
Compound 4: middle estimate off by 1.1-fold (0.03 log units), on the low side; the range from low to high includes it.
By their numbers in this assay, from the lowest: compounds 2, 1, 3 and 4 (each within the scatter of the next).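

Exchanging the cyclohexyl for hydrogen on the aromatic carbon para to the (2-carboxyethenyl)carbonyl group gives, in this assay, a 1.4-fold higher number from compound 2 to compound 4 (0.14 log units; within the scatter). Among these compounds, this is the first single-place comparison, and it shows that this carbon can carry either a cyclohexyl or a hydrogen with no difference that can be read in this assay, which the earlier compounds, differing in more than one place, could not show. No measured evidence bears on why the two compounds match.

As far as these compounds go, whether an amine, a carboxylic acid or a longer chain on this same carbon would also stay within the scatter of compound 2 remains open. So does whether the match between cyclohexyl and hydrogen would hold without the methyl groups of compound 2 and compound 4.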